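Aminothiophene series: ring-nitrogen substituent swap, third step

This account rests on a few compounds, and the source may have more. Where it says the series, first, only, none or still open, it means among the compounds named here.

Three measured compounds share one core and differ only in the group on the amine nitrogen in the ring. In a functional assay on CHO cells with adenosine receptor A1 (Homo sapiens) as the target, read by cAMP accumulation and immunoassay, with a stated time of 6 min, tested at 10 uM (on this read-out lower numbers stand for a stronger effect and higher numbers for a weaker effect at the one concentration tested), compound 3 `Nc1scc(CN2CCN(CCCc3ccc(Cl)cc3)CC2)c1C(=O)c1ccc(Cl)cc1` gives -76%, the highest of the three numbers. Compound 2 `Nc1scc(CN2CCN(c3c(F)cc(F)cc3F)CC2)c1C(=O)c1ccc(Cl)cc1` gives -78%, and compound 1 `Nc1scc(CN2CCN(c3cc(F)ccc3F)CC2)c1C(=O)c1ccc(Cl)cc1` gives -80%. Both steps to compound 3 stayed within scatter: a number 4 percentage points higher from compound 1 to compound 3 (within the scatter), and a number 2 percentage points higher from compound 2 to compound 3 (within the scatter). Compound 4 `Nc1scc(CN2CCN(c3ccc(Cl)c(Cl)c3)CC2)c1C(=O)c1ccc(Cl)cc1` is not yet measured; the change from compound 3 is 3,4-dichlorophenyl in place of 3-(4-chlorophenyl)propyl on an amine nitrogen in a ring Both earlier steps exchanged a six-membered aromatic ring of carbon only for the propyl chain at this nitrogen without moving beyond scatter, so no step beyond scatter is expected here either. The expected step is a number 2 percentage points lower from compound 3 to compound 4 (within the scatter). For compound 4 the estimate in this assay is -78%, ranging from -92% to -62%.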

Compound 4, a percentage reported as activity, at one concentration (the size of the read-out at that concentration, not a potency): -62%
Compound 4: middle estimate off by 16 percentage points, on the low side, and the stated range covers the measured number.
By their numbers in this assay, from the lowest: compounds 1, 2 and 3 (each within the scatter of the next); then compound 4.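

The group on this nitrogen can move the read-out in this assay: the change gives a number 14 percentage points higher from compound 3 to compound 4 (beyond the scatter) and a number 16 percentage points higher from compound 2 to compound 4 (beyond the scatter) and also a number 18 percentage points higher from compound 1 to compound 4 (beyond the scatter) with 3,4-dichlorophenyl in place. An aromatic ring of carbon only bound to this nitrogen does not settle the number, since 2,5-difluorophenyl and 2,4,6-trifluorophenyl stay within the scatter of the propyl-linked group while 3,4-dichlorophenyl does not. Nothing available explains this step.

Open, going by these compounds, is whether the shift needs both chlorines or follows from one alone. Also open, on these data alone, is how a methoxy group or a carboxylic acid on that phenyl ring would read.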